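The source may hold more compounds than are shown below. What is called first, only, known or untested is meant among the compounds shown, and "the series" means these compounds.

Three compounds share one core and differ only in the group attached to a saturated chain carbon. Compound 1 `Cn1ncc(Cl)c1-c1cc(C(=O)N[C@@H]2CN[C@H](CC(=O)O)C[C@H]2c2ccc(Cl)c(Cl)c2)oc1Cl` carries a carboxylic acid there, and in a functional assay on LNCaP cells (Homo sapiens) for antiproliferative activity (on this read-out lower numbers stand for stronger inhibition and higher numbers for weaker inhibition), compound 1 gives 640 nM. Compound 2 `Cn1ncc(Cl)c1-c1cc(C(=O)N[C@@H]2CN[C@H](CC(=O)NC3CCC3)C[C@H]2c2ccc(Cl)c(Cl)c2)oc1Cl` gives 80 nM in this assay, and compound 3 `CNC(=O)C[C@@H]1C[C@@H](c2ccc(Cl)c(Cl)c2)[C@H](NC(=O)c2cc(-c3c(Cl)cnn3C)c(Cl)o2)CN1` gives 40 nM. Compound 3 thus shows the lowest of the three numbers, although compound 2 lies within the usual scatter of it; only compound 1 stands clearly apart, through a 16-fold lower number from compound 1 to compound 3 (1.20 log units; beyond the scatter) and an 8.0-fold lower number from compound 1 to compound 2 (0.90 log units; beyond the scatter), whereas a 2.0-fold lower number from compound 2 to compound 3 (0.30 log units; within the scatter). Compound 4 `Cn1ncc(Cl)c1-c1cc(C(=O)N[C@@H]2CN[C@H](CCN3CCCCC3)C[C@H]2c2ccc(Cl)c(Cl)c2)oc1Cl` alters compound 3 in a single place: (piperidin-1-yl)methyl in place of methylcarbamoyl on a saturated chain carbon bound to a saturated ring carbon. Among the measured compounds shown here, none of the measured steps bears directly on this change: the two steps from compound 1 show that an amide in place of the acid gave lower numbers, and the step between the two amides shows that the group on the amide nitrogen hardly mattered. For the measured compounds named here, no measured compound lacks the carbonyl of this side chain, so what the amine does is open. A step of a 3.0-fold higher number from compound 3 to compound 4 (0.48 log units; beyond the scatter) toward a somewhat higher number is expected, with wide uncertainty. Compound 4 is therefore estimated at 120 nM, in a range from 25 nM to 600 nM.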

Compound 4, half-maximal inhibitory concentration: 1780 nM
The estimate for compound 4 lay 15-fold (1.17 log units) below the measured number, outside the stated range (above it).
By their numbers in this assay, from the lowest: compounds 3 and 2 (each within the scatter of the next); then compound 1; then compound 4.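

In this assay, the group on a saturated chain carbon bound to a saturated ring carbon matters far more than the two amides suggested: (piperidin-1-yl)methyl gives a 45-fold higher number from compound 3 to compound 4 (1.65 log units; beyond the scatter), and likewise a 22-fold higher number from compound 2 to compound 4 (1.35 log units; beyond the scatter). Compound 4 also stands clearly apart from the acid, with a 2.8-fold higher number from compound 1 to compound 4 (0.44 log units; beyond the scatter), so among these four compounds the amine side chain gives the highest number, above even the carboxylic acid that had given the highest so far. Nothing available accounts for this loss.

This one change removes the carbonyl and the amide hydrogen and brings in the piperidine ring, so the compounds shown do not separate these differences. Open, therefore, is how a piperidin-1-ylcarbonyl group, which keeps the carbonyl with the same ring, or a dimethylaminomethyl group, which keeps the amine without the ring, would read out at this place.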